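Swapping a sulfonyl cap for a piperidine amide

This account rests on a few compounds, and the source may have more. Where it says the series, first, only, none or still open, it means among the compounds named here.

Measured so far:
- compound 1, `O=S(=O)(NC1CCN(S(=O)(=O)c2ccccc2)CC1)c1cc(S(=O)(=O)c2ccccc2)ccc1C(F)(F)F`: 130 nM
- compound 2, `CC(C)(C)OC(=O)N1CCC(CC(=O)N2CCC(NS(=O)(=O)c3cc(S(=O)(=O)c4ccccc4)ccc3C(F)(F)F)CC2)CC1`: 490 nM

Both compounds were tested in an assay on isolated protein for displacement of a labelled ligand from secreted frizzled-related protein 1 (Homo sapiens), read by fluorescence polarization, with a stated time of 30 min; on this read-out lower numbers stand for stronger inhibition and higher numbers for weaker inhibition. Compound 1 gives 130 nM, and compound 2 gives 490 nM. Of these two numbers, compound 1 has the lower one, and the gap between them is beyond the usual scatter of repeated measurements, so compound 1 is the stronger binder among the two.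

Compound 3, `O=C(C1CCNCC1)N1CCC(NS(=O)(=O)c2cc(S(=O)(=O)c3ccccc3)ccc2C(F)(F)F)CC1`, has not yet been measured. It keeps the core of compound 1 and changes one group: (piperidin-4-yl)carbonyl in place of phenylsulfonyl on an amine nitrogen in a ring. The group that leaves is an aromatic sulfonyl cap; the group that enters is an amide carrying a ring amine with a hydrogen-bond donor. Within the data shown here, no pair differing in exactly this way has been measured, so the size of the step is uncertain. A modest move toward weaker inhibition is expected in this assay, because compound 2, which also carries an amide at this nitrogen, gives 490 nM. The expected step from compound 1 is a 3.1-fold higher number from compound 1 to compound 3 (0.49 log units; beyond the scatter). Compound 3 is therefore estimated at 400 nM, within a range from 130 nM to 1500 nM.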

Compound 3, half-maximal inhibitory concentration: 120 nM
For compound 3 the middle estimate is 3.3-fold (0.52 log units) above the measured one, and the stated range ends above it.
By their numbers in this assay, from the lowest: compounds 3 and 1 (each within the scatter of the next); then compound 2.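

In this assay, the step is a 1.1-fold lower number from compound 1 to compound 3 (0.03 log units; within the scatter), so at this amine nitrogen in a ring, (piperidin-4-yl)carbonyl and phenylsulfonyl cannot be told apart by this read-out. This is new information about the position: the number stays within the scatter even though the six-membered aromatic ring of carbon only and the sulfonyl give way to a non-aromatic ring with 1 hetero atom, a carbonyl and a hydrogen-bond donor, so neither the aromatic ring nor the sulfonyl is required here to keep binding in this range. No measurement on hand explains why the two caps give such closely matched numbers.

On these data alone, it remains open whether the ring nitrogen of the entering group matters at all, a question that cyclohexylcarbonyl, with carbon in place of that nitrogen, or an N-methylpiperidine version of the same amide could address. Among these compounds, it is also open how far this position tolerates other kinds of group, such as a simple acetyl cap or a chain ending in a carboxylic acid, since only one step at this nitrogen can be read so far.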